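A few compounds are considered here, and "the series" means these few. Any claim that something is new, unique, unknown or untested is made for them only; others in the source may bear on it.

Measured in an ADME assay on L02 cells (Homo sapiens) for antiproliferative activity, read by MTT assay, with a stated time of 48 h; a higher number here means a weaker inhibitor, a lower number a stronger inhibitor:
Compound 1 `N#CC1=C(N)Oc2c(N)cc3nc4ccccc4nc3c2C12C(=O)N(Cc1cnnn1-c1ccccc1Br)c1ccccc12` gives 29200 nM.
Compound 2 `COc1ccc(-n2nncc2CN2C(=O)C3(C(C#N)=C(N)Oc4c(N)cc5nc6ccccc6nc5c43)c3ccccc32)cc1` gives > 50000 nM, which is a limit of the assay.
Compound 3 `COc1ccccc1-n1nncc1CN1C(=O)C2(C(C#N)=C(N)Oc3c(N)cc4nc5ccccc5nc4c32)c2ccccc21` gives > 50000 nM, which is a limit of the assay.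

Compound 3 thus stands at the upper end of what this assay reports, sharing the limit of > 50000 nM in this assay, at which 2 of the 3 values shown sit, with one other compound in the set, so only a floor for its number is known. Compound 4 `CCc1cccc(CC)c1-n1nncc1CN1C(=O)C2(C(C#N)=C(N)Oc3c(N)cc4nc5ccccc5nc4c32)c2ccccc21` carries 2,6-diethylphenyl in place of 2-methoxyphenyl on an aromatic nitrogen. Within the data shown here, two measured steps touch the same part of the structure. The change on the aromatic carbon of that phenyl gave an at least 1.7-fold higher number from compound 1 to compound 3 (0.23 log units; that floor lies within the scatter), and the move of the methoxy from one position to the other gave a step that the two limits leave unreadable from compound 2 to compound 3. Neither step points toward a lower number, and both ended at the limit. For compound 4 the expectation is therefore a step that the limit leaves unreadable from compound 3 to compound 4, most likely again a limit rather than a number. Compound 4 is estimated at 60000 nM, in the range 20000 nM to 150000 nM.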

Compound 4, half-maximal inhibitory concentration: > 50000 nM
Compound 4: a limit, no number; the forecaster's own chance of this, stated with the estimate: 70%; the middle value does not contradict the limit.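

In this assay compound 4 gives > 50000 nM, which is a limit of the assay and not a number. The limit is therefore not tied to a methoxy group on this phenyl: 2,6-diethylphenyl, made of carbon only, reaches it too, with an at least 1.7-fold higher number from compound 1 to compound 4 (0.23 log units; that floor lies within the scatter). The steps to compound 4 from compound 2 and compound 3 cannot be read, and most of the position now rests on a single limit: the limit of > 50000 nM in this assay, at which 3 of the 4 values shown sit.

Among these compounds, compound 1, with its 2-bromophenyl group, remains the only compound here with a measured number, at 29200 nM. Open, going by these compounds, is whether 2-chlorophenyl, unsubstituted phenyl or a phenyl bearing an amine or a carboxylic acid on this aromatic nitrogen would also give a number rather than a limit.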